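This account rests on a few compounds, and the source may have more. Where it says the series, first, only, none or still open, it means among the compounds named here.

Compound 1 `C=CCCCCCC#CC#CCO` is the reference point of this small set. Among the measured compounds shown here, in a functional assay on HCT-15 cells (Homo sapiens) for cytotoxicity (a higher number here means that more compound is needed for the effect, a lower number that less compound is needed), compound 1 gives 12.9 ug/mL, the highest of the three numbers measured so far; the two other compounds each sit well beyond the scatter from it. Compound 2 `C=CCCCCCC#CC#CC(O)CC(C)=O` gives 3.42 ug/mL in this assay, and the step of a 3.8-fold lower number from compound 1 to compound 2 (0.58 log units; beyond the scatter) corresponds to 2-oxopropyl in place of hydrogen on a saturated chain carbon bound to an oxygen on a saturated carbon and a triple-bonded carbon. Compound 3 `C=CCCCCCCCC#CC#CCO` gives 3.32 ug/mL, and the step of a 3.9-fold lower number from compound 1 to compound 3 (0.59 log units; beyond the scatter) corresponds to but-3-en-1-yl in place of vinyl on a saturated chain carbon, five bonds along the chain from a triple-bonded carbon.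

Compound 4 `C=CCCCCCC#CC#CCOCCO` is not yet measured. It differs from compound 1 in one place: 2-hydroxyethyl in place of hydrogen on an oxygen on a saturated carbon. Neither measured step is the same change, but both add atoms to compound 1 and both lowered the number by a modest amount; the step from compound 1 to compound 2, which also adds to the hydroxyl end, is the closer precedent. A modest lowering is therefore expected, as a 2.0-fold lower number from compound 1 to compound 4 (0.30 log units; within the scatter), though smaller than either measured step is plausible. Compound 4 is estimated at 6.5 ug/mL in this assay, with a range from 2.5 ug/mL to 16 ug/mL.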

Compound 4, concentration for half-maximal effect: 24.1 ug/mL
For compound 4 the middle estimate is 3.7-fold (0.57 log units) below the measured one; the measured number lies above the stated range.
By their numbers in this assay, from the lowest: compounds 3 and 2 (each within the scatter of the next); then compounds 1 and 4 (each within the scatter of the next).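

Among the compounds shown here, the oxygen on a saturated carbon had carried only its hydrogen in compounds 1, 2 and 3, so compound 4 is the first of the set to test a substituent on that atom. In this assay, 2-hydroxyethyl in place of that hydrogen gives a 1.9-fold higher number from compound 1 to compound 4 (0.27 log units; within the scatter), whereas the two earlier additions, 2-oxopropyl on the neighbouring chain carbon in a 3.8-fold lower number from compound 1 to compound 2 (0.58 log units; beyond the scatter) and but-3-en-1-yl in place of vinyl at the far end in a 3.9-fold lower number from compound 1 to compound 3 (0.59 log units; beyond the scatter), each moved the number beyond the scatter, so among these compounds an added group does not by itself shift the read-out, and this oxygen tolerates substitution by 2-hydroxyethyl without a resolved change. Nothing among the data shown accounts for this difference between the positions.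

Since 2-hydroxyethyl brings a hydroxyl of its own, compound 4 alone cannot separate substitution on the oxygen from the presence of a terminal hydroxyl, a question that a methyl ether or an acetate ester at this oxygen would address. On these data alone, it also remains open whether a longer chain or an amine at the end of the 2-hydroxyethyl group would give a step beyond the scatter.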